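The source may report more compounds than this note shows. Statements on the series, on what has been measured and on what is new or still open speak of the compounds shown alone.

Going by the values given here, in a functional assay on the whole organism for inhibition of sodium-dependent dopamine transporter (Mus musculus) (a lower number here means that less compound is needed, a higher number that more compound is needed for the effect), compound 2 `CCOC(=O)Nc1cccc2c1CN(C)CC2c1ccc(Cl)cc1` gives 21 mg/kg, the lowest of the two numbers known so far. Its nearest neighbour, compound 1 `CCCCNC(=O)Nc1cccc2c1CN(C)CC2c1ccc(Cl)cc1`, gives about 120 mg/kg. Among the compounds with values here, the single known step, a 5.7-fold lower number from compound 1 to compound 2 (0.76 log units; beyond the scatter), came from ethoxy in place of butylamino on a carbonyl carbon. Compound 3 `CCCCNCC(=O)Nc1cccc2c1CN(C)CC2c1ccc(Cl)cc1` now carries the change ((butylamino)methyl in place of ethoxy on a carbonyl carbon). That one step bears on it only loosely, since the butylamino group returns in compound 3 as part of (butylamino)methyl, and compound 1 with its butylamino gave the higher number. A modest rise is therefore expected, a 2.4-fold higher number from compound 2 to compound 3 (0.38 log units; beyond the scatter). Compound 3 is estimated at 50 mg/kg, within 15 mg/kg to 170 mg/kg.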

Compound 3, dose for half-maximal effect: 22 mg/kg
Beside the measured number, compound 3's estimate is 2.3-fold (0.36 log units) above it; low and high end bracket the measured number.
By their numbers in this assay, from the lowest: compounds 2 and 3 (each within the scatter of the next); then compound 1.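

On the carbonyl carbon whose other neighbour is the amide-type nitrogen, ethoxy and the larger (butylamino)methyl give numbers within the scatter of each other (a 1.0-fold higher number from compound 2 to compound 3 (0.02 log units; within the scatter)). The butylamino group therefore does not by itself go with the higher number, since (butylamino)methyl in place of butylamino gives a clear drop (a 5.5-fold lower number from compound 1 to compound 3 (0.74 log units; beyond the scatter)). No evidence here explains either step.

Open, from the compounds shown here alone, is what an aminomethyl group without the butyl chain, or a longer chain on that amine nitrogen, would give at this carbonyl carbon.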